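A Small Methyl Step Repeated on a Second Core

This account rests on a few compounds, and the source may have more. Where it says the series, first, only, none or still open, it means among the compounds named here.

Compound 1 `CCn1cc(-c2nc3ccccc3s2)c(=O)c2cc(F)c(N3CCNCC3)cc21` and compound 2 `CCn1cc(-c2nc3ccccc3s2)c(=O)c2cc(F)c(N3CCN(C)CC3)cc21` share one core. In a functional assay on Bel-7402 cells (Homo sapiens) for cytotoxicity, read by MTT assay, with a stated time of 48 h (a lower number here means a stronger inhibitor, a higher number a weaker inhibitor), compound 1 gives 24300 nM, and compound 2 gives 24000 nM. The change between them, (methyl in place of hydrogen on an amine nitrogen in a ring), made the step of a 1.0-fold lower number from compound 1 to compound 2 (0.01 log units; within the scatter). Compound 3 `CCn1cc(-c2nc3ccc([N+](=O)[O-])cc3[nH]2)c(=O)c2cc(F)c(N3CCNCC3)cc21` carries a different core; the difference between the two cores is not broken down here. In this assay compound 3 gives 2100 nM, the lowest of the three numbers, and its gap to each of the other two lies beyond the scatter. Compound 4 `CCn1cc(-c2nc3ccc([N+](=O)[O-])cc3[nH]2)c(=O)c2cc(F)c(N3CCN(C)CC3)cc21` is not yet measured and differs from compound 3 by methyl in place of hydrogen on an amine nitrogen in a ring, the same change at the same place as that between compound 1 and compound 2. Compound 4 is expected to repeat that step, giving no change at the digits printed from compound 3 to compound 4 (within the scatter), because the same change gave a 1.0-fold lower number from compound 1 to compound 2 (0.01 log units; within the scatter). Compound 4 is therefore estimated at 2100 nM in this assay, with a likely range from 1000 nM to 4500 nM.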

Compound 4, half-maximal inhibitory concentration: 4400 nM
Compound 4: the middle estimate sits 2.1-fold (0.32 log units) below what was measured; measured number inside the range.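

In this assay, the methyl change on the second core gives a 2.1-fold higher number from compound 3 to compound 4 (0.32 log units; beyond the scatter), a modest step. Set beside the first step, the two results cannot be told apart, so the change carries from one core to the other as far as these data can show: the same change on two cores in this assay, a 1.0-fold lower number (0.01 log units; within the scatter) from compound 1 to compound 2 and a 2.1-fold higher number (0.32 log units; beyond the scatter) from compound 3 to compound 4, 2.1-fold (0.33 log units) apart, within the scatter of two such steps This rests on only one pair of compounds per core, so it does not show that the step would hold on any further core, and it says nothing about why the step has this size.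

The compounds shown carry only hydrogen or methyl on the amine nitrogen in the ring. As far as these compounds go, how a longer chain such as propyl, or an acetyl group, would behave at that place remains open.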